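The source may hold more compounds than are shown below. What is called first, only, known or untested is meant among the compounds shown, and "the series" means these compounds.

Measured so far in an ADME assay on microsomes from liver (Homo sapiens) for metabolic stability, with a stated time of 30 min; a higher number here means that more of the compound is left, a lower number that less of the compound is left:

- compound 1 `CCCCOC(=O)Cc1c(C(C)C)nc(CCCC)n(Cc2ccc(-c3ccccc3-c3noc(=O)[nH]3)cc2)c1=O`: 7.1%
- compound 2 `CCCCc1nc(C(C)C)c(CC(=O)OC2CC2)c(=O)n1Cc1ccc(-c2ccccc2-c2noc(=O)[nH]2)cc1`: 10.3%

Compound 2 stands highest of the two numbers; the nearest is compound 1, and the step of a number 3.2 percentage points higher from compound 1 to compound 2 (within the scatter) lies within the scatter, so no order between the two can be read from this.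

Compound 3 `CCCCc1nc(C(C)C)c(CC(=O)OC2CCCCC2)c(=O)n1Cc1ccc(-c2ccccc2-c2noc(=O)[nH]2)cc1` differs from compound 2 by cyclohexyl in place of cyclopropyl on an oxygen next to a carbonyl group. Going by the values given here, the only measured step that bears on it is the exchange at the same oxygen next to a carbonyl group, from compound 1 to compound 2, which stayed within the scatter. On that basis, no step beyond the scatter is expected from compound 2 to compound 3 in this assay, i.e. an expected step of a number 1.3 percentage points lower from compound 2 to compound 3 (within the scatter). Compound 3 is therefore estimated at 9%, with a range from 3% to 20%.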

Compound 3, percent of the compound remaining: 13.3%
Compound 3: middle estimate off by 4.3 percentage points, on the low side; the range from low to high includes it.
By their numbers in this assay, from the lowest: compounds 1, 2 and 3 (each within the scatter of the next).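

In this assay, the exchange on an oxygen next to a carbonyl group now spans butyl, cyclopropyl and cyclohexyl, and the new steps are a number 3 percentage points higher from compound 2 to compound 3 (within the scatter) and a number 6.2 percentage points higher from compound 1 to compound 3 (within the scatter). Across these three compounds, neither ring size nor the swap between an open chain and a ring gives a step beyond the scatter, so this position has not yet separated any pair among them. No evidence is available that bears on this result.

Open, from the compounds shown here alone, is whether a chain carrying an amine on this oxygen, or a hydrogen there to give the carboxylic acid, would produce a step beyond the scatter. Also open, going by these compounds, is how this read-out responds to exchanges elsewhere on the shared core, since all three compounds differ at this one place only.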